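Swapping a Methyl for a Nitro Group

The compounds below may be only part of what the source reports. "The series", "measured", "known", "first", "only" and "open" are said of these compounds alone.

Measured so far:
compound 1, `CCOc1cccc2cc(-c3ccc([N+](=O)[O-])cc3)c(=O)oc12`: > 100000 nM
compound 2, `Cc1ccc(-c2cc3cccc(C)c3oc2=O)cc1`: > 100000 nM

Both compounds were tested in an assay on CHO cells for displacement of a labelled ligand from adenosine receptor A1 (Homo sapiens), read by radioligand binding; a lower number here means a stronger inhibitor, a higher number a weaker inhibitor. For compound 1 the value > 100000 nM is a limit of the assay, not a measured number. For compound 2 the value > 100000 nM is likewise a limit. Going by these compounds, compound 2 therefore stands at the limit of > 100000 nM in this assay, at which 2 of the 2 values shown sit, so its real strength is unknown except that it is weak.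

Compound 3, `Cc1cccc2cc(-c3ccc([N+](=O)[O-])cc3)c(=O)oc12`, is compound 2 with one change, (nitro in place of methyl on an aromatic carbon), that is, nitro in place of methyl on an aromatic carbon. Among the compounds with values here, no measured pair shows this change directly. Compound 1, which carries the same nitro group, also sits at a limit. A step from compound 2 to compound 3 in this assay of any size beyond the usual scatter is therefore not expected, and the estimated step is a number no higher from compound 2 to compound 3 (the limit leaves the size open). For compound 3 the expected value is 100000 nM, within a range from 30000 nM to 300000 nM.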

Compound 3, inhibition constant: > 100000 nM
Compound 3: no number, only a limit; the forecaster's own chance of this, stated with the estimate: 85%; the middle value lies on the limit itself.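

Within the data shown here, compound 1, compound 2 and compound 3 all stop at a limit rather than a measured number, so no step between them can be read: the limit of > 100000 nM in this assay, at which 3 of the 3 values shown sit.

The compounds shown leave open how strong each one really is, and whether putting nitro in place of methyl changes that strength at all.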